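Compound 4: bromo in place of chloro

The source may hold more compounds than are shown below. What is called first, only, known or untested is meant among the compounds shown, and "the series" means these compounds.

Three compounds of the series have values in a functional assay on liver (Rattus norvegicus, strain Sprague-Dawley) for inhibition, with a stated time of 1 h; on this read-out lower numbers stand for stronger inhibition and higher numbers for weaker inhibition. Compound 1 (`COc1ccc(C(=O)OCC2Oc3ccc([C@H]4Oc5cc(O)cc(O)c5C(=O)[C@@H]4O)cc3OC2c2ccc(O)c(OC)c2)cc1`) gives 21000 nM, compound 2 (`COc1cc(C2Oc3cc([C@H]4Oc5cc(O)cc(O)c5C(=O)[C@@H]4O)ccc3OC2COC(=O)c2cc([N+](=O)[O-])cc([N+](=O)[O-])c2)ccc1O`) gives 14600 nM and compound 3 (`COc1cc(C2Oc3cc([C@H]4Oc5cc(O)cc(O)c5C(=O)[C@@H]4O)ccc3OC2COC(=O)/C=C/c2ccc(Cl)cc2)ccc1O`) gives 12000 nM. Compound 3 stands within the scatter of both other compounds.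

Compound 4 (`COc1cc(C2Oc3cc([C@H]4Oc5cc(O)cc(O)c5C(=O)[C@@H]4O)ccc3OC2COC(=O)/C=C/c2ccc(Br)cc2)ccc1O`) differs from compound 3 in one place, with bromo in place of chloro on an aromatic carbon, para to a large group: bromo in place of chloro on an aromatic carbon.

Among the compounds with values here, no measured step exchanges one halogen for another. The nearest evidence is the replacement of the whole group on the carbonyl carbon, where a 1.8-fold lower number from compound 1 to compound 3 (0.24 log units; within the scatter) and a 1.2-fold lower number from compound 2 to compound 3 (0.09 log units; within the scatter) stay within the scatter, as does a 1.4-fold lower number from compound 1 to compound 2 (0.16 log units; within the scatter). A step beyond the scatter is therefore not expected in this assay, and neither direction is favoured. The expected step is no change at the digits printed from compound 3 to compound 4 (within the scatter). The estimate for compound 4 is 12000 nM, with an expected range of 7000 nM to 20000 nM.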

Compound 4, half-maximal inhibitory concentration: 16300 nM
The estimate for compound 4 lay 1.4-fold (0.13 log units) below the measured number, and the stated range covers the measured number.
By their numbers in this assay, from the lowest: compounds 3, 2, 4 and 1 (each within the scatter of the next).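

In this assay, within the data shown here, this is the first direct halogen exchange on this aromatic carbon, para to a large group, and it gives a 1.4-fold higher number from compound 3 to compound 4 (0.13 log units; within the scatter), so chloro and bromo are not told apart here. Set against the other groups on the carbonyl carbon, 2-(4-bromophenyl)ethenyl gives a 1.1-fold higher number from compound 2 to compound 4 (0.05 log units; within the scatter) and a 1.3-fold lower number from compound 1 to compound 4 (0.11 log units; within the scatter), so it joins 3,5-dinitrophenyl, 4-methoxyphenyl and 2-(4-chlorophenyl)ethenyl with no separation among the four. No measurement available bears on the reason for this reading.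

From the compounds shown here alone, whether an amine or a carboxylic acid in place of bromo on that aromatic carbon, or a longer chain in place of the 2-(4-bromophenyl)ethenyl group, would give a step beyond the scatter remains open. The compounds shown also leave open whether any part of the shared core governs the read-out in this assay.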